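The source may report more compounds than this note shows. Statements on the series, on what has been measured and on what is new or still open speak of the compounds shown alone.

Measured compounds:
- compound 1 `O=C(Cc1csc2nc(-c3ccc(Br)cc3)cn12)N/N=C/c1ccccc1`: 7410 nM in a functional assay on RPMI-8226 cells (Homo sapiens) for inhibition, read by sulforhodamine B assay, with a stated time of 48 h; a higher number here means a weaker inhibitor of growth, a lower number a stronger inhibitor of growth
- compound 2 `O=C(Cc1csc2nc(-c3ccc(Br)cc3)cn12)N/N=C/c1ccccc1O`: 2820 nM in this assay

Among the measured compounds shown here, compound 2 has the lowest of the two numbers in this assay; the only other one is compound 1, and the change was a 2.6-fold lower number from compound 1 to compound 2 (0.42 log units; beyond the scatter). Compound 3 `O=C(Cc1csc2nc(-c3ccc(Br)cc3)cn12)N/N=C/c1ccc(Cl)cc1Cl` differs from compound 2 by 2,4-dichlorophenyl in place of 2-hydroxyphenyl on a carbon with a double bond to nitrogen. For the measured compounds named here, only that one measured step speaks to this change, and it concerns just the hydroxy group that now leaves; the entering chlorines have no precedent here. Removing the hydroxy group is expected to hand back roughly what it brought, so compound 3 is estimated at 5500 nM (range 2000 nM to 15000 nM), a step of a 2.0-fold higher number from compound 2 to compound 3 (0.29 log units; within the scatter).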

Compound 3, concentration for 50% growth inhibition: 79400 nM
Compound 3: the middle estimate sits 14-fold (1.16 log units) below what was measured, outside the stated range (above it).
By their numbers in this assay, from the lowest: compound 2; then compound 1; then compound 3.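

In this assay, this position does more than lose what the hydroxy group brought: the change to 2,4-dichlorophenyl gives a 28-fold higher number from compound 2 to compound 3 (1.45 log units; beyond the scatter). Measured against the plain phenyl, it still gives an 11-fold higher number from compound 1 to compound 3 (1.03 log units; beyond the scatter), so adding the chlorines here makes growth inhibition clearly weaker, not merely no better. No evidence on the cause of this loss is available. The compounds shown leave open whether a single chlorine would weaken inhibition as much as the pair. They also leave open whether a methoxy group or an amine on this ring would match the hydroxy group.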